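The compounds below may be only part of what the source reports. "The series", "measured", "known", "first", "only" and "open" are said of these compounds alone.

Measured compounds in a functional assay on the whole organism (strain albino) for inhibition, with Rattus norvegicus as the target, read by paw edema, with stated times of 30 min and 5 h, at a dose of 100 mg/kg by the oral route; on this read-out lower numbers stand for less inhibition and higher numbers for more inhibition at the one dose given (going by the name of the read-out):

Compound 1, `COc1ccc(/C=C/C(=O)c2ccc(NC(=O)CBr)cc2)cc1`: 34%
Compound 2, `COc1ccc(/C=C/C(=O)c2ccc(NC(=O)CO[N+](=O)[O-])cc2)cc1`: 46%
Compound 3, `CC(O[N+](=O)[O-])C(=O)Nc1ccc(C(=O)/C=C/c2ccc(Cl)cc2)cc1`: 56%

Compound 3 gives the largest of the three numbers in this assay. Its gap to compound 2 is within the scatter, so the two cannot be ordered; its gap to compound 1 is beyond the scatter. Within the data shown here, the one single-place step measured is a number 12 percentage points higher from compound 1 to compound 2 (beyond the scatter), a change on the chain rather than on the ring.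

Compound 4, `COc1ccc(/C=C/C(=O)c2ccc(NC(=O)C(C)O[N+](=O)[O-])cc2)cc1`, is the next entry. Against compound 3 the difference is methoxy in place of chloro on an aromatic carbon. Among the measured compounds shown here, no measured single-place step touches this ring position. Compounds 2 and 3 differ in more than one place, so their values say only that a methoxy-bearing and a chloro-bearing member of the series sit within the scatter of each other in this assay. The modest step from compound 1 to compound 2 does not bear on a ring change. On this footing no step beyond the scatter is expected for a number 6 percentage points lower from compound 3 to compound 4 (within the scatter). Compound 4 is therefore estimated at 50%, with a range from 38% to 62%.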

Compound 4, a percentage reported as inhibition, in the whole organism at one dose (the size of the read-out at that dose, not a potency): 35%
Estimate against measurement, compound 4: 15 percentage points above; measured number below the stated range.
By their numbers in this assay, from the lowest: compounds 1 and 4 (each within the scatter of the next); then compounds 2 and 3 (each within the scatter of the next).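

In this assay, the position on the aromatic ring para to a large group proves able to move the read-out: 4-methoxyphenyl in place of 4-chlorophenyl gives a number 21 percentage points lower from compound 3 to compound 4 (beyond the scatter) on an otherwise unchanged structure. The chain carbon bearing the nitrooxy group also matters with the 4-methoxyphenyl held constant, since methyl in place of hydrogen there gives a number 11 percentage points lower from compound 2 to compound 4 (beyond the scatter) and so takes away the gain seen in a number 12 percentage points higher from compound 1 to compound 2 (beyond the scatter) when bromomethyl is compared with the unbranched nitrooxy chain; 1-(nitrooxy)ethyl in place of bromomethyl gives a number 1 percentage points higher from compound 1 to compound 4 (within the scatter) and leaves that pair unordered. No available evidence bears on the cause of either the ring step or the chain steps.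

Whether the methyl step carries over to the 4-chlorophenyl side remains open, as does whether the ring step holds with the unbranched nitrooxy chain, since compound 3 is the only chloro-bearing member shown. The compounds shown also say nothing about fluoro, an amine or a carboxylic acid on the ring, or about a longer chain such as ethyl in place of the methyl.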